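A new group on the carbonyl of compound 1

A few compounds are considered here, and "the series" means these few. Any claim that something is new, unique, unknown or untested is made for them only; others in the source may bear on it.

- compound 1 `COc1cc2nccc(Oc3ccc4c(NC(=O)c5cccc(C(F)(F)F)c5)nn(C)c4c3)c2cc1OC` gives 9 nM
- compound 2 `COc1cc2nccc(Oc3ccc4c(NC(=O)c5cc(C(F)(F)F)cc(C(F)(F)F)c5)nn(C)c4c3)c2cc1OC` gives 58 nM

Among the measured compounds shown here, in a functional assay on HUVEC cells (Homo sapiens) for inhibition, with stated times of 2 h and 72 h (on this read-out lower numbers stand for stronger inhibition and higher numbers for weaker inhibition), compound 1 holds the lower of the two numbers so far, and compound 2 lies clearly above it. Compound 3 `COc1cc2nccc(Oc3ccc4c(NC(=O)Nc5ccc(C(F)(F)F)cc5Cl)nn(C)c4c3)c2cc1OC` keeps the shared core of compound 1 but differs on a carbonyl carbon whose other neighbours are an amide-type nitrogen. The difference is (2-chloro-4-(trifluoromethyl)phenyl)amino in place of 3-(trifluoromethyl)phenyl on a carbonyl carbon and it is larger than any change measured so far.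

For the measured compounds named here, only one measured step bears on this, and only in part. That step is a 6.4-fold higher number from compound 1 to compound 2 (0.81 log units; beyond the scatter) and it came with trifluoromethyl in place of hydrogen on an aromatic carbon. Compound 3 likewise carries an extra group on its aromatic ring, a chlorine, so a modest rise in this assay is expected, probably smaller than that step. Going by the values given here, no measured compound shows what the entering nitrogen does, so the range stays wide.

The expected step is a 2.2-fold higher number from compound 1 to compound 3 (0.35 log units; beyond the scatter) and it remains an estimate. For compound 3 the estimated value is 20 nM with an expected range from 4 nM to 100 nM in this read-out.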

Compound 3, half-maximal inhibitory concentration: 1150 nM
Compound 3: the middle estimate sits 58-fold (1.76 log units) below what was measured; the whole stated range lies below it.
By their numbers in this assay, from the lowest: compound 1; then compound 2; then compound 3.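

Putting (2-chloro-4-(trifluoromethyl)phenyl)amino in place of 3-(trifluoromethyl)phenyl on the carbonyl carbon gives a 130-fold higher number from compound 1 to compound 3 (2.11 log units; beyond the scatter) in this assay and is a far larger move than the earlier one, a 6.4-fold higher number from compound 1 to compound 2 (0.81 log units; beyond the scatter). The earlier pair showed only that a second trifluoromethyl on the aromatic ring carries a modest cost, whereas this result shows that the number can climb much further with a change at this place, one that brings in an amide-type nitrogen with one hydrogen-bond donor along with a chlorine. Nothing available explains why the number rises so far.

Several things change at once in compound 3, so the nitrogen, the chlorine and the altered placing of the trifluoromethyl cannot be told apart, and the step cannot be credited to any one of them. On these data alone, whether a plain phenylamino group or a 3-(trifluoromethyl)phenylamino group on the carbonyl carbon would stay close to compound 1 or rise towards compound 3 remains open.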